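Cytotoxicity notes on an indole-glyoxamide polyamine pair

The compounds below may be only part of what the source reports. "The series", "measured", "known", "first", "only" and "open" are said of these compounds alone.

Measured so far:
- compound 1, `NCCCCNCCCNC(=O)C(=O)c1c[nH]c2cc(Br)ccc12`: 25000 nM
- compound 2, `CC(C)(C)OC(=O)NCCCCNCCCNC(=O)C(=O)c1c[nH]c2ccccc12`: 73000 nM

Compound 2, `CC(C)(C)OC(=O)NCCCCNCCCNC(=O)C(=O)c1c[nH]c2ccccc12`, in an ADME assay on L6 cells (Rattus norvegicus) for cytotoxicity, read by resazurin assay, with a stated time of 72 h (a lower number here means a stronger inhibitor, a higher number a weaker inhibitor), gives 73000 nM. Of the two numbers in hand this is the higher one; compound 1 gives 25000 nM, and the gap between the two lies beyond the scatter. The two compounds differ in more than one place, so no single step can be read from them.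

Compound 3, `CC(C)(C)OC(=O)NCCCCNCCCNC(=O)C(=O)c1c[nH]c2cc(Br)ccc12`, is not yet measured. It differs from compound 2 in one place: bromo in place of hydrogen on an aromatic carbon. For the measured compounds named here, no measured pair shows this change on its own. The carbamate end is shared with compound 2, so the expected step from compound 2 to compound 3 is small, tending toward a lower number, estimated at a 1.5-fold lower number from compound 2 to compound 3 (0.16 log units; within the scatter). Compound 3 is accordingly expected to give about 50000 nM in this assay, within a range of 20000 nM to 120000 nM.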

Compound 3, half-maximal inhibitory concentration: 25000 nM
Compound 3: the middle estimate sits 2.0-fold (0.30 log units) above what was measured; low and high end bracket the measured number.
By their numbers in this assay, from the lowest: compounds 1 and 3 (each within the scatter of the next); then compound 2.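

In this assay, for the compounds shown here, bromo in place of hydrogen on an aromatic carbon of the shared core, with the tert-butoxycarbonyl end held constant, gives a 2.9-fold lower number from compound 2 to compound 3 (0.47 log units; beyond the scatter) as the only single-place reading of this change, and a modest one. With the 6-bromo-1H-indol-3-yl end held constant, tert-butoxycarbonyl in place of hydrogen on the amine nitrogen gives no change at the digits printed from compound 1 to compound 3 (within the scatter) as the matching reading at the far end of the chain, so this pair shows no separation between the capped and uncapped nitrogen. Nothing in hand bears on the origin of either reading.

Going by these compounds, whether chloro or methoxy on the same aromatic carbon would give a step like that of bromo remains open. So does whether an acetyl group on the amine nitrogen, or a longer chain, would alter the number.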